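A few compounds are considered here, and "the series" means these few. Any claim that something is new, unique, unknown or untested is made for them only; others in the source may bear on it.

In a functional assay on SNB-75 cells (Homo sapiens) for inhibition, read by sulforhodamine B assay, with a stated time of 48 h (a lower number here means a stronger inhibitor of growth, a higher number a weaker inhibitor of growth), compound 2 `COc1cc(-c2nn(-c3cccc(NC(=O)Nc4cccc(C(F)(F)F)c4)c3)cc2-c2ccncc2)ccc1Cl` gives 4500 nM. Among the two numbers so far it holds the lowest, with compound 1 `COc1cc(-c2nn(-c3cccc(NC(=O)Nc4ccc(Cl)c(Cl)c4)c3)cc2-c2ccncc2)ccc1Cl` nearest at 5170 nM, and the two lie within the usual scatter of each other, so no order between them can be claimed. Going by the values given here, the single measured step, a 1.1-fold lower number from compound 1 to compound 2 (0.06 log units; within the scatter), is a swap of one aromatic group for another on the amide-type nitrogen, and it left the number essentially unmoved. Compound 3 `COc1cc(-c2nn(-c3cccc(NC(=O)c4ccc(Cl)c(C(F)(F)F)c4)c3)cc2-c2ccncc2)ccc1Cl` is reached by a different kind of change, (4-chloro-3-(trifluoromethyl)phenyl in place of (3-(trifluoromethyl)phenyl)amino on a carbonyl carbon). Among the compounds with values here, no measured step touches the carbonyl carbon in this way, so the step from compound 1 to compound 2 bears on it only loosely, by showing that changes in this region have so far stayed inside the scatter. The step from compound 2 to compound 3 is therefore expected to be small, a 1.1-fold higher number from compound 2 to compound 3 (0.05 log units; within the scatter), with no clear direction. Compound 3 is estimated at 5000 nM, between 1500 nM and 16000 nM.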

Compound 3, concentration for total growth inhibition: 29200 nM
For compound 3 the middle estimate is 5.8-fold (0.77 log units) below the measured one; the whole stated range lies below it.
By their numbers in this assay, from the lowest: compounds 2 and 1 (each within the scatter of the next); then compound 3.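

Unlike the aryl swap between compound 1 and compound 2, which stayed within the scatter, a change at the carbonyl carbon does move the number in this assay: 4-chloro-3-(trifluoromethyl)phenyl in place of (3-(trifluoromethyl)phenyl)amino gives a 6.5-fold higher number from compound 2 to compound 3 (0.81 log units; beyond the scatter). The same holds against the other aryl amino group, with a 5.6-fold higher number from compound 1 to compound 3 (0.75 log units; beyond the scatter), so the result does not depend on which of the two amino groups is replaced. Nothing available explains why the number rises.

This change removes the amino nitrogen with its hydrogen-bond donor and also adds a chlorine, and the compounds shown do not separate these two differences. On these data alone, how a methylene or an oxygen in place of that nitrogen would read in this assay remains open.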